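An anilino swap on the shared core in a growth assay

This account rests on a few compounds, and the source may have more. Where it says the series, first, only, none or still open, it means among the compounds named here.

Of the compounds shown here, three built on one shared core have so far been tested in a functional assay on MCF7 cells (Homo sapiens) for inhibition, read by sulforhodamine B assay; on this read-out lower numbers stand for stronger inhibition and higher numbers for weaker inhibition. Compound 1 `Cc1ccc(NC2=CC(=O)c3nc4n(c3C2=O)[C@H]2OC[C@@H](O)[C@H]2OC4)cc1` gives 1660 nM. Compound 2 `COc1cccc(NC2=CC(=O)c3c(nc4n3[C@H]3OC[C@@H](O)[C@H]3OC4)C2=O)c1` gives 3830 nM, the highest of the two numbers recorded; its nearest neighbour is compound 1, whose number lies lower by a margin beyond the usual scatter. Compound 3 `CCOc1ccccc1NC1=CC(=O)c2nc3n(c2C1=O)[C@H]1OC[C@@H](O)[C@H]1OC3` reaches only a limit in this assay, at > 4000 nM. Going by the values given here, the single step measured in one place is an at least 2.4-fold higher number from compound 1 to compound 3 (0.38 log units; beyond the scatter), and its size can only be given as a bound because the limit of > 4000 nM in this assay, at which 1 of the 3 values shown sits, is where that value sits.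

Compound 4 `O=C1C(Nc2ccc(Br)cc2)=CC(=O)c2c1nc1n2[C@H]2OC[C@@H](O)[C@H]2OC1` has not yet been measured. It differs from compound 2 in one place: 4-bromophenyl in place of 3-methoxyphenyl on an amine nitrogen. Among the compounds with values here, no measured step covers this particular exchange. The step from compound 1 to compound 3 shows that changing the aryl group on the amine nitrogen can move the number in this assay, at least modestly, so a shift of similar order is plausible here, while the 4-methylphenyl of compound 1, with its lower number than compound 2, suggests the direction downward. Compound 4 is therefore expected to give about 2000 nM in this assay, between 800 nM and 5000 nM. That estimate amounts to a 1.9-fold lower number from compound 2 to compound 4 (0.28 log units; within the scatter).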

Compound 4, half-maximal inhibitory concentration: 4330 nM
Beside the measured number, compound 4's estimate is 2.2-fold (0.34 log units) below it, and the stated range covers the measured number.
By their numbers in this assay, from the lowest: compound 1; then compounds 2 and 4 (each within the scatter of the next).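

In this assay, the exchange of 3-methoxyphenyl for 4-bromophenyl on the amine nitrogen leaves the number within the scatter, at a 1.1-fold higher number from compound 2 to compound 4 (0.05 log units; within the scatter). The earlier step had shown only that an aryl exchange at this nitrogen can raise the number; this one shows that an exchange here need not move it at all, even though the entering group carries a bromine in place of a methoxy group and that group is named at a different ring position. Compound 1, with its 4-methylphenyl, gives 1660 nM, which remains the lowest number shown, so neither compound 2 nor compound 4 reads lower than that compound in this growth assay.

Still open is how the number would respond to a plain phenyl, a 4-chlorophenyl or a saturated cyclohexyl group on the same amine nitrogen, since every group shown there is a substituted phenyl. Compound 3 remains a limit, so its place relative to compound 2 and compound 4 cannot be read: the limit of > 4000 nM in this assay, at which 1 of the 4 values shown sits.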